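A few compounds are considered here, and "the series" means these few. Any claim that something is new, unique, unknown or untested is made for them only; others in the source may bear on it.

Compound 1 `CC1=CC[C@H](C(C)(C)N=C=S)CC1` gives in a functional assay on NCI/ADR-RES cells (Homo sapiens) for inhibition, read by sulforhodamine B assay, with a stated time of 48 h (on this read-out higher numbers stand for weaker inhibition of growth and lower numbers for stronger inhibition of growth), a value that is a limit of the assay, > 100000 nM. Compound 2 `CC1=CC[C@H](C(C)(C)NC(=S)NN)CC1` gives in this assay 39300 nM. Compound 3 `COc1ccc(/C=N/NC(=S)NC(C)(C)[C@H]2CC=C(C)CC2)cc1` gives in this assay 43800 nM.

Among the two numbers that are not limits, compound 3 stands highest, and its nearest neighbour is compound 2, whose number sits within the scatter of that of compound 3; the third value, that of compound 1, is a limit (the limit of > 100000 nM in this assay, at which 1 of the 3 values shown sits). Going by the values given here, the one measured step, an at least 2.5-fold lower number from compound 1 to compound 2 (0.40 log units; beyond the scatter), concerns the group on the saturated chain carbon of the shared core and not the aryl group of the hydrazone end.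

Compound 4 `CC1=CC[C@H](C(C)(C)NC(=S)N/N=C/c2cccc(Cl)c2)CC1` differs from compound 3 by 3-chlorophenyl in place of 4-methoxyphenyl on a carbon with a double bond to nitrogen. Among the compounds with values here, no measured step touches this part of the molecule, so the step from compound 3 to compound 4 has no direct precedent here. In this assay compound 4 is therefore expected to sit close to compound 3, with a step of a 1.1-fold lower number from compound 3 to compound 4 (0.04 log units; within the scatter) that is not expected to exceed the scatter. The estimate for compound 4 is 40000 nM, within a range of 14000 nM to 110000 nM.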

Compound 4, concentration for 50% growth inhibition: 67500 nM
Estimate against measurement, compound 4: 1.7-fold (0.23 log units) below; the range from low to high includes it.
By their numbers in this assay, from the lowest: compounds 2, 3 and 4 (each within the scatter of the next). At a limit, above all of these: compound 1.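

The aryl group on the carbon with a double bond to nitrogen changes here for the first time among the compounds shown, and 3-chlorophenyl in place of 4-methoxyphenyl gives a 1.5-fold higher number from compound 3 to compound 4 (0.19 log units; within the scatter) in this assay. This exchange therefore replaces one substituted phenyl ring with another, differing in both substituent and its printed position, without separating the two compounds on this read-out. No measured finding shown here bears on the cause of this step.

The compounds shown leave open whether a phenyl ring carrying an amine or a carboxylic acid would move the number beyond the scatter. They also leave open what a longer chain in place of the phenyl ring on this carbon would do, and whether 4-chlorophenyl would sit with compound 3 and compound 4.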